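Permeability of Four Alkyl-Substituted Core Compounds

This account rests on a few compounds, and the source may have more. Where it says the series, first, only, none or still open, it means among the compounds named here.

Measured in an ADME assay for permeability, using PAMPA, at pH 7.4; on this read-out higher numbers stand for higher permeability and lower numbers for lower permeability:
- Compound 1 `Cc1[nH]c2ccccc2c(=O)c1C1CCCCC1`: 230 10^-6 cm/s
- Compound 2 `Cc1[nH]c2ccccc2c(=O)c1Br`: 13.6 10^-6 cm/s
- Compound 3 `CCCCC#Cc1c(C)[nH]c2ccc(OC)cc2c1=O`: 2440 10^-6 cm/s

Of these three, compound 3 stands highest, and its distance from both compound 1 and compound 2 lies beyond the scatter. Compound 4 `CCCCC#Cc1c(C)[nH]c2ccccc2c1=O` has not yet been measured. It departs from compound 3 by one change, hydrogen in place of methoxy on an aromatic carbon. Within the data shown here, no measured step covers this exchange. The only one available, a 17-fold lower number from compound 1 to compound 2 (1.23 log units; beyond the scatter), is large, but it concerns bromo in place of cyclohexyl and offers little guidance here. No shift beyond the scatter is therefore expected in this assay, and the expected step is a 1.2-fold lower number from compound 3 to compound 4 (0.09 log units; within the scatter). For compound 4 the estimated value is 2000 10^-6 cm/s, with an expected range of 800 10^-6 cm/s to 5000 10^-6 cm/s.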

Compound 4, apparent permeability: 2140 10^-6 cm/s
Beside the measured number, compound 4's estimate is 1.1-fold (0.03 log units) below it, and the stated range covers the measured number.
By their numbers in this assay, from the lowest: compound 2; then compound 1; then compounds 4 and 3 (each within the scatter of the next).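

In this assay, hydrogen in place of methoxy on an aromatic carbon gives a 1.1-fold lower number from compound 3 to compound 4 (0.06 log units; within the scatter), so this exchange stays within the scatter. Among these compounds, compound 4 also places the hex-1-yn-1-yl group on the same core as the earlier compounds, with a 160-fold higher number from compound 2 to compound 4 (2.20 log units; beyond the scatter) for its exchange with bromo and a 9.3-fold higher number from compound 1 to compound 4 (0.97 log units; beyond the scatter) for its exchange with cyclohexyl. No available evidence accounts for these steps.

The compounds shown leave open whether an amine or a carboxylic acid in place of methoxy would also stay within the scatter. They also leave open how a longer chain in place of hex-1-yn-1-yl would compare.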